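Acetyl in place of isopropyl: compound 3 awaiting measurement

The source may report more compounds than this note shows. Statements on the series, on what has been measured and on what is new or still open speak of the compounds shown alone.

Measured so far in an ADME assay on microsomes from liver (Mus musculus) for metabolic stability, read by LC-MS, using NADPH, with stated times of 15 min and 60 min, tested at 4.6 uM (a lower number here means that the compound disappears faster, a higher number that the compound lasts longer), for this series:
- compound 1 `CC(C)CNC(=O)n1c(=O)oc2ccc(C3CCN(C)CC3)cc21` at 0.667 h
- compound 2 `CC(C)N1CCC(c2ccc3c(c2)oc(=O)n3C(=O)NCCCCc2ccccc2)CC1` at 1 h

Among the compounds with values here, compound 2 lies within the usual scatter of compound 1, the only other compound measured, so these two values set no order between them. Taken together, they give a single level of half-life for the series so far, and two compounds are too few to support any pattern.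

The next compound to be read is compound 3 `CC(=O)N1CCC(c2ccc3c(c2)oc(=O)n3C(=O)NCCCCc2ccccc2)CC1`, which has acetyl in place of isopropyl on an amine nitrogen in a ring when set against compound 2 acetyl in place of isopropyl on an amine nitrogen in a ring and keeps the rest of that structure.

Within the data shown here, no pair of measured compounds isolates this change, so the data offer no direct guide to its size or direction. With compound 2 at 1 h as the only starting point, the expected outcome is a step of a 1.2-fold higher number from compound 2 to compound 3 (0.08 log units; within the scatter) that stays within the scatter in this assay and has no firm direction. The estimate for compound 3 is 1.2 h with an expected range from 0.5 h to 3 h for now.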

Compound 3, half-life: 1 h
Compound 3: middle estimate off by 1.2-fold (0.08 log units), on the high side, within the range that was stated.
By their numbers in this assay, from the lowest: compounds 1, 2 and 3 (each within the scatter of the next).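

In this assay, within the data shown here, the swap at this position gives the first step that can be read directly, no change at the digits printed from compound 2 to compound 3 (within the scatter), and this is the only pair that differs in one place. Going from 1-isopropylpiperidin-4-yl to 1-acetylpiperidin-4-yl adds a carbonyl and a hydrogen-bond acceptor on the amine nitrogen in a ring while keeping the same count of heavy atoms, yet the half-life shows no response on this background, something compound 1 could not show as it differs from compound 2 in more than one place. Nothing at hand accounts for this result.

From the compounds shown here alone, it remains open whether a methanesulfonyl group, a carboxylic acid or a longer acyl chain on the same nitrogen would move the half-life beyond the scatter. Going by these compounds, it is also open whether acetyl in place of isopropyl would read the same way with a different group on the rest of the structure, as a single pair cannot support a rule for the series.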